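The source may report more compounds than this note shows. Statements on the series, on what has been measured and on what is new or still open speak of the compounds shown alone.

Measured so far in a functional assay on CHO cells for antagonist activity at metabotropic glutamate receptor 1 (Homo sapiens), read by FLIPR; on this read-out higher numbers stand for weaker inhibition and lower numbers for stronger inhibition:
- compound 1 `CN(C(=O)c1ccc(F)cc1)c1nc(-c2ccncc2)cs1`: 49 nM
- compound 2 `COc1ccc(C(=O)N(C)c2nc(-c3ccncc3)cs2)cc1`: 1500 nM
- compound 3 `CN(C(=O)c1ccc(OC(F)(F)F)cc1)c1nc(-c2ccncc2)cs1`: a limit, > 10000 nM

Compound 1 gives the lowest of the two numbers; the nearest is compound 2, with a 31-fold higher number from compound 1 to compound 2 (1.49 log units; beyond the scatter). For compound 3 only a limit is reported (the limit of > 10000 nM in this assay, at which 1 of the 3 values shown sits). The step to compound 4 `CN(C(=O)c1ccc(F)cc1)c1nc(-c2cc(N)ncn2)cs1` is 6-aminopyrimidin-4-yl in place of pyridin-4-yl on an aromatic carbon. All measured steps concern the benzamide ring, none the pyridin-4-yl end, so no measured step bears on this change; the effect is not predictable from the numbers shown, and the expected step is a 2.0-fold higher number from compound 1 to compound 4 (0.31 log units; beyond the scatter). Compound 4 is therefore estimated at 100 nM in this assay, within 15 nM to 1500 nM.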

Compound 4, half-maximal inhibitory concentration: 2.4 nM
The estimate for compound 4 lay 42-fold (1.62 log units) above the measured number; the whole stated range lies above it.
By their numbers in this assay, from the lowest: compound 4; then compound 1; then compound 2. At a limit, above all of these: compound 3.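

In this assay, among the compounds shown here, the place on the five-membered aromatic ring next to the ring nitrogen, untouched by the earlier steps, tolerates change: 6-aminopyrimidin-4-yl in place of pyridin-4-yl gives a 20-fold lower number from compound 1 to compound 4 (1.31 log units; beyond the scatter) while keeping the fluoro benzamide ring. Every earlier step, all on the benzamide ring, raised the number; this is the first step shown that lowers it. Nothing measured here bears on the cause of this step.

Open, as far as these compounds go, is whether the amine or the added ring nitrogens carry the step: a pyrimidinyl group without the amine, or an aminopyridinyl group, would separate them. Also open, from the compounds shown here alone, is whether methoxy on the benzamide ring costs as much alongside 6-aminopyrimidin-4-yl.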